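Five-membered ring swaps on the shared core: working notes

The compounds below may be only part of what the source reports. "The series", "measured", "known", "first", "only" and "open" are said of these compounds alone.

Compound 1, `O=C(O)c1cc(-c2ncco2)ccc1O`: in a functional assay on the whole organism for inhibition, with Rattus norvegicus as the target, read by paw edema (on this read-out higher numbers stand for an effect only at larger amounts of compound and lower numbers for an effect already at smaller amounts), compound 1 gives 100 mg/kg.
Compound 2, `O=C(O)c1cc(-c2csnn2)ccc1O`: compound 2 gives only a limit, > 200 mg/kg.
Compound 3, `O=C(O)c1cc(-c2nccs2)ccc1O`: compound 3 gives only a limit, > 250 mg/kg.

Compound 3 therefore stands at a limit, not a number, and one further value in this set is also a limit, so its rank among the three cannot be fixed. Compound 4, `O=C(O)c1cc(-n2cnnc2)ccc1O`, differs from compound 3 in one place: 4H-1,2,4-triazol-4-yl in place of 1,3-thiazol-2-yl on an aromatic carbon. Bearing on it are the two steps away from the 1,3-oxazol-2-yl group: an at least 2.0-fold higher number from compound 1 to compound 2 (0.30 log units; that floor lies within the scatter) and an at least 2.5-fold higher number from compound 1 to compound 3 (0.39 log units; beyond the scatter); the remaining step is a step that the two limits leave unreadable from compound 2 to compound 3. Both ring replacements so far ended at limits, so for compound 4 the expected step is a number no higher from compound 3 to compound 4 (the limit leaves the size open). Compound 4 is estimated at 250 mg/kg, range 100 mg/kg to 600 mg/kg, most likely reported again as a limit.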

Compound 4, dose for half-maximal effect: > 250 mg/kg
Compound 4: no number, only a limit (the forecaster's own chance of this, stated with the estimate: 65%); the middle value sits exactly at the limit.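

Compound 4 gives only a limit in this assay, > 250 mg/kg. With 4H-1,2,4-triazol-4-yl, a ring without sulfur, the change from 1,3-oxazol-2-yl still gives an at least 2.5-fold higher number from compound 1 to compound 4 (0.39 log units; beyond the scatter), so among these compounds a limit is not confined to the sulfur-bearing rings. The steps among compound 2, compound 3 and compound 4 cannot be read, and the same limit recurs: the limit of > 250 mg/kg in this assay, at which 2 of the 4 values shown sit.

Still open, as far as these compounds go, is how far these three rings actually differ, since none gives a number. Also open, from the compounds shown here alone, is whether an amine or a phenyl group at this position would give a number, as 1,3-oxazol-2-yl does.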